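This account rests on a few compounds, and the source may have more. Where it says the series, first, only, none or still open, it means among the compounds named here.

Compound 2 `CCCCN(CC)c1cc(C)nc2c1NC(=O)CN2c1ccc(Br)cc1Br` was tested in an assay on HEK-293T cells for displacement of a labelled ligand from corticotropin-releasing factor receptor 2 (Homo sapiens), read by scintillation counting, with a stated time of 2 h, tested at 1 uM; on this read-out higher numbers stand for more inhibition at the one concentration tested (going by the name of the read-out) and lower numbers for less inhibition. In this assay compound 2 gives 9.4%. Among the compounds with a reported number it stands highest of two, but only just: the other number comes from compound 1 `CCCCN(CC)c1cc(C)nc2c1NC(=O)CN2c1ccc(C)cc1C`, and in this assay compound 1 gives 6.8%. The step between them, a number 2.6 percentage points higher from compound 1 to compound 2 (within the scatter), put 2,4-dibromophenyl in place of 2,4-dimethylphenyl on a nitrogen of the shared core and stays within the scatter, so the two values cannot be told apart. Compound 3 `CCCCN(CC)c1cc(C)nc2c1NC(=O)CN2c1ccc(I)cc1C` belongs to the same series, but in this assay compound 3 is given as "not determined" (no result reported), so no result was reported for it.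

Compound 4 `CCCCN(CC)c1cc(C)nc2c1NC(=O)CN2c1ccc(Br)cc1CC` differs from compound 2 in one place: ethyl in place of bromo on an aromatic carbon. Among the measured compounds shown here, the only measured step bears on this change loosely, since going from compound 1 to compound 2 exchanged methyl groups for bromo groups on the same phenyl ring and moved the read-out by little. Turning one bromo back into a carbon chain, here ethyl, is therefore expected to leave the read-out essentially unchanged, and the step of a number 1.4 percentage points lower from compound 2 to compound 4 (within the scatter) is estimated to lie within the scatter. Compound 4 is estimated at 8% in this assay, with a range from 0% to 20%.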

Compound 4, a percentage reported as inhibition, at one concentration (the size of the read-out at that concentration, not a potency): 2.1%
Compound 4: middle estimate off by 5.9 percentage points, on the high side, within the range that was stated.
By their numbers in this assay, from the lowest: compounds 4, 1 and 2 (each within the scatter of the next).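

Exchanging bromo for ethyl on this aromatic carbon, ortho to a large group, gives a number 7.3 percentage points lower from compound 2 to compound 4 (within the scatter), so in this assay these two groups cannot be told apart at this position. The wider change from 2,4-dimethylphenyl to 4-bromo-2-ethylphenyl gives a number 4.7 percentage points lower from compound 1 to compound 4 (within the scatter), which means that neither a single exchange at this position nor the change across the phenyl ring separates the three compounds with a reported number. No independent measurement is available to explain why these numbers stay so close together.

Going by these compounds, all three compounds carry small groups on the phenyl ring and give only small percentages at the one concentration tested, so it remains open whether a longer chain such as butyl, an amine or a carboxylic acid on this aromatic carbon would give a number clearly different from the others. The place of the iodo-bearing compound 3 in this group also remains open, since it has no reported result, and a reading at one concentration gives no potency for any of these compounds.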